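The source may hold more compounds than are shown below. What is called first, only, known or untested is meant among the compounds shown, and "the series" means these compounds.

Measured so far:
compound 1 `COc1ccc2[nH]cc(C(=O)NCC3CCNCC3)c2c1`: 42%
compound 2 `CCN1CCC(NC(=O)c2cc(Cl)c(N)cc2OC)CC1`: > 100%

Compound 1 gives 42% in a functional assay on HEK293 cells for activation of 5-hydroxytryptamine receptor 4 (Homo sapiens), read by cAMP accumulation (on this read-out higher numbers stand for larger maximal responses and lower numbers for smaller maximal responses), a partial response. Compound 2 is reported in this assay only as a limit, > 100%, not as a number. Compound 2 thus sits at the top of what is shown, at the limit of > 100% in this assay, at which 1 of the 2 values shown sits, and no step between measured compounds is available for the series.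

Compound 3 `COc1cc(N)c(Cl)cc1C(=O)NC1CCN(CCCCCCCCS(=O)(=O)O)CC1` is not yet measured in this assay. It differs from compound 2 by 6-sulfohexyl in place of hydrogen on a saturated chain carbon, two bonds along the chain from an amine nitrogen in a ring. For the measured compounds named here, with compound 2 already at a limit and no measured step to lean on, the expected step of a number at least 5 percentage points lower from compound 2 to compound 3 (that floor lies within the scatter) is none beyond the scatter, with a slight lean toward a smaller maximal response. Compound 3 is therefore estimated at 95% in this assay, with a range from 70% to 110%.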

Compound 3, intrinsic activity: the largest response reached, in percent of the reference agonist's: > 100%
Compound 3 gave a limit, no number; the forecaster's own chance of this, stated with the estimate: 35%; middle value at least 5 percentage points away from the limit.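

Compound 2 and compound 3 both stand only as limits in this assay, and the step between them cannot be read. The compounds shown leave open what number either one would carry, and whether 6-sulfohexyl in place of hydrogen changes the maximal response at all.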